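Acetylation of the Ring Hydroxyl in a Butenolide Series

The compounds below may be only part of what the source reports. "The series", "measured", "known", "first", "only" and "open" are said of these compounds alone.

The study concerns a small set of lactones carrying a butyl chain and an acetoxy group, tested in a functional assay on LUC1 cells (Homo sapiens) for cytotoxicity, read by sulforhodamine B assay, with a stated time of 48 h; a higher number here means that more compound is needed for the effect, a lower number that less compound is needed. Compound 1, `CCCC[C@H](OC(C)=O)[C@@H](O)[C@H](O)[C@@H]1OC(=O)C=C[C@@H]1OC(C)=O`, gives 8.8 ug/mL in this assay. Compound 2, `CCCC[C@@H](/C=C\[C@@H]1OC(=O)C=C[C@@H]1O)OC(C)=O`, gives 2.3 ug/mL and so stands at the lowest number among the two values that are reported as numbers, with compound 1 sitting further up by a margin beyond the usual scatter. Compound 3, `CCCC[C@@H](/C=C\[C@@H]1OC(=O)C[C@@H](OC)[C@@H]1O)OC(C)=O`, is reported in this assay only as a limit, > 20 ug/mL, and not as a number; it is one of the compounds described by the limit of > 20 ug/mL in this assay, at which 1 of the 3 values shown sits.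

The unmeasured compound is compound 4, `CCCC[C@@H](/C=C\[C@@H]1OC(=O)C=C[C@@H]1OC(C)=O)OC(C)=O`. It differs from compound 2 in one place: acetyl in place of hydrogen on an oxygen on a saturated carbon. For the measured compounds named here, no step between two measured compounds that differ in a single place is available, so the size of this change cannot be read from a measured pair. Compound 1 carries the same acetyl group at the corresponding position, but its other differences from compound 2 prevent a direct reading. The expectation is therefore for a step of no more than the usual scatter in either direction, a 1.3-fold higher number from compound 2 to compound 4 (0.12 log units; within the scatter). Compound 4 is accordingly estimated at 3 ug/mL in this assay, with a range from 1.2 ug/mL to 8 ug/mL.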

Compound 4, concentration for half-maximal effect: 0.9 ug/mL
The estimate for compound 4 lay 3.3-fold (0.52 log units) above the measured number; measured number outside the range, below it.
By their numbers in this assay, from the lowest: compound 4; then compound 2; then compound 1. At a limit, above all of these: compound 3.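

In this assay, replacing hydrogen with acetyl on this oxygen gives the series its first step that can be read from a measured pair differing in one place: a 2.6-fold lower number from compound 2 to compound 4 (0.41 log units; beyond the scatter). The earlier compounds shown here could not show this, as compound 1 carries the same acetyl group but differs from the others in further places, so its value could not isolate the change. The step shows that the free hydroxy on this saturated ring carbon is not needed for the effect in this pair, and that hydroxy to acetoxy here moves the number down by more than the usual scatter, although no measurement shown bears on why it does so.

The compounds shown leave open whether this shift belongs to acetyl in particular or would also appear with a propanoyl or benzoyl ester, or with a carbamate, on the same oxygen. They also leave open whether the same change would act alike on the core of compound 1, and what part the other acetoxy group plays, since this single step speaks only for one pair in one cell line.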